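The source may hold more compounds than are shown below. What is called first, only, known or untested is meant among the compounds shown, and "the series" means these compounds.

Compound 1, with structure `O=C(/C=C/c1ccc(OCCCCCO[N+](=O)[O-])c(O)c1)OCCCCCO[N+](=O)[O-]`, is the starting point of this account. In a functional assay on A549 cells (Homo sapiens) for cytotoxicity, read by resazurin assay, with a stated time of 72 h (a higher number here means a weaker inhibitor, a lower number a stronger inhibitor), compound 1 gives 450 nM. Compound 2, with structure `O=C(/C=C/c1ccc(OCCCCO[N+](=O)[O-])c(O)c1)OCCCCO[N+](=O)[O-]`, carries a different core; the difference between the two cores is not broken down here. In this assay compound 2 gives 410 nM, and the two values of compound 1 and compound 2 sit within the usual scatter of each other, so neither can be called the stronger.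

Compound 3, with structure `COc1cc(/C=C/C(=O)OCCCCCO[N+](=O)[O-])ccc1OCCCCCO[N+](=O)[O-]`, differs from compound 1 by methyl in place of hydrogen on an oxygen on an aromatic ring. For compound 3 this assay reports only a limit, > 50000 nM, which is the limit of > 50000 nM in this assay, at which 1 of the 3 values shown sits. The change from compound 1 to compound 3 therefore reads as an at least 110-fold higher number from compound 1 to compound 3 (2.04 log units; beyond the scatter).

Compound 4, with structure `COc1cc(/C=C/C(=O)OCCCCO[N+](=O)[O-])ccc1OCCCCO[N+](=O)[O-]`, has not yet been measured in this assay. For the measured compounds named here, its relation to compound 2 is methyl in place of hydrogen on an oxygen on an aromatic ring, which is the same change as the one from compound 1 to compound 3, at the same place. Compound 4 is therefore expected to follow compound 3, and the step from compound 2 to compound 4 is estimated as a 120-fold higher number from compound 2 to compound 4 (2.09 log units; beyond the scatter), resting on the size of an at least 110-fold higher number from compound 1 to compound 3 (2.04 log units; beyond the scatter) seen when compound 1 became compound 3. For compound 4 the expected value in this assay is 50000 nM, with a plausible range from 6000 nM to 200000 nM, and there is a good chance that only a limit is reported.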

Compound 4, half-maximal inhibitory concentration: > 50000 nM
Compound 4: a limit, no number; the forecaster's own chance of this, stated with the estimate: 75%; the middle value lies on the limit itself.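

In this assay compound 4 is reported only as a limit, > 50000 nM. The change from hydroxy to methoxy, which gave an at least 110-fold higher number from compound 1 to compound 3 (2.04 log units; beyond the scatter) on the core of compound 1, carries over in the same direction to the core of compound 2 and there gives an at least 120-fold higher number from compound 2 to compound 4 (2.08 log units; beyond the scatter). This shows that on both of these cores the methoxy compound reads far weaker than its hydroxy partner, but it gives no exact size for either step and does not show that the two steps are equal or extend to any core beyond these two: the same change on two cores in this assay, an at least 110-fold higher number (2.04 log units; beyond the scatter) from compound 1 to compound 3 and an at least 120-fold higher number (2.08 log units; beyond the scatter) from compound 2 to compound 4; the limit leaves it open whether they differ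

The compounds shown leave open whether the free hydroxy is itself required, or whether another group on that oxygen, such as an ethyl or an acetyl, or an amine in place of the hydroxy, would keep the values seen for compound 1 and compound 2. Also open, from the compounds shown here alone, is what a longer or shorter chain would do on the hydroxy core, and how that core would read with an amide in place of the ester or with a plain hydroxy in place of the nitrate at the chain ends.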